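The source may report more compounds than this note shows. Statements on the series, on what has been measured and on what is new or still open speak of the compounds shown alone.

Values so far in a functional assay on A549 cells (Homo sapiens) for antiproliferative activity, read by MTT assay, with a stated time of 48 h; a lower number here means a stronger inhibitor, a higher number a weaker inhibitor:
compound 1 `COc1ccc(/C=C/c2cc(OC)cc(OC)c2/C=C/C(=O)c2ccc(Cl)c(Cl)c2)cc1` gives 5.9 ug/mL
compound 2 `CCCCOc1ccc(C(=O)/C=C/c2c(/C=C/c3ccc(OC)cc3)cc(OC)cc2OC)cc1` gives 8.7 ug/mL

Compound 2 at 8.7 ug/mL stands within the scatter of compound 1 at 5.9 ug/mL and the pair cannot be ranked. Next comes compound 3 `COc1ccc(/C=C/c2cc(OC)cc(OC)c2/C=C/C(=O)c2cccc(Cl)c2)cc1` with 3-chlorophenyl in place of 4-butoxyphenyl on a carbonyl carbon. For the measured compounds named here, the only measured step at this place is a 1.5-fold higher number from compound 1 to compound 2 (0.17 log units; within the scatter) and it came with 4-butoxyphenyl in place of 3,4-dichlorophenyl on a carbonyl carbon. This single step stays inside the scatter. Of the compounds shown here, two show no trend, and nothing measured so far points to a large move in this assay for the new compound. The expected change is a 1.3-fold lower number from compound 2 to compound 3 (0.13 log units; within the scatter) and no step beyond the scatter is expected. Compound 3 is estimated at 6.5 ug/mL with an expected range from 3 ug/mL to 14 ug/mL in this assay.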

Compound 3, half-maximal inhibitory concentration: 5.6 ug/mL
Compound 3: the middle estimate sits 1.2-fold (0.06 log units) above what was measured, within the range that was stated.
By their numbers in this assay, from the lowest: compounds 3, 1 and 2 (each within the scatter of the next).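

In this assay, hydrogen in place of chloro on an aromatic carbon gives the smallest change yet at this place, a 1.1-fold lower number from compound 1 to compound 3 (0.02 log units; within the scatter), so the 3,4-dichlorophenyl and 3-chlorophenyl groups cannot be told apart. The larger exchange of 3-chlorophenyl in place of 4-butoxyphenyl on the carbonyl carbon, with fewer heavy atoms entering than leaving and the hydrogen-bond acceptor gone, gives a 1.6-fold lower number from compound 2 to compound 3 (0.19 log units; within the scatter), which also stays inside the scatter, so the three groups at this place remain unranked across compounds 1, 2 and 3. No measured property of these groups is at hand to speak to this result.

As far as these compounds go, all three compounds carry a phenyl group with no net charge on this carbonyl carbon, so it remains open whether an amine, a carboxylic acid or a pyridine ring there would shift the number beyond the scatter. From the compounds shown here alone, how a hydroxyl group in place of a methoxy group on the shared core would compare with these steps is likewise open.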